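The source may hold more compounds than are shown below. What is called first, only, known or untested is meant among the compounds shown, and "the series" means these compounds.

Compound 1, `CCSc1nn2cc(-c3cc4ccccc4o3)nc2s1`: 2900 nM in a functional assay on HEK293 cells for antagonist activity at proteinase-activated receptor 4 (Homo sapiens), read by FLIPR and calcium flux, with a stated time of 30 min; on this read-out higher numbers stand for weaker inhibition and lower numbers for stronger inhibition.
Compound 2, `COc1nn2cc(-c3cc4c(OC)cccc4o3)nc2s1`: 7.6 nM in this assay.

Of these two numbers, compound 1 carries the highest, meaning the weaker inhibition; compound 2 sits at a far lower number, and the gap between them lies well beyond the scatter of repeated measurements. For the measured compounds named here, compound 2 differs from compound 1 in more than one place, so no single step between them can be traced.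

Compound 3, `CCOc1nn2cc(-c3cc4ccccc4o3)nc2s1`, has not yet been measured. It differs from compound 1 in one place only: ethoxy in place of ethylsulfanyl on an aromatic carbon. Going by the values given here, no measured compound carries ethoxy in that place on its own, so the expectation rests on compound 1 at 2900 nM and on the much lower number seen with compound 2. The step of a 9.7-fold lower number from compound 1 to compound 3 (0.99 log units; beyond the scatter) is expected to bring stronger inhibition. Compound 3 is estimated at 300 nM, with a range from 60 nM to 1500 nM.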

Compound 3, half-maximal inhibitory concentration: 67 nM
Estimate against measurement, compound 3: 4.5-fold (0.65 log units) above; low and high end bracket the measured number.
By their numbers in this assay, from the lowest: compound 2; then compound 3; then compound 1.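

Ethoxy and ethylsulfanyl match in every count computed here, including heavy atoms, hydrogen-bond donors and acceptors, and net charge, yet the exchange of sulfur for oxygen gives a 43-fold lower number from compound 1 to compound 3 (1.64 log units; beyond the scatter) in this assay. This aromatic carbon, next to the ring nitrogen and next to the ring sulfur, therefore responds strongly to the identity of the atom that carries the two-carbon chain, even though the chain itself stays the same. No measured evidence here bears on the reason for this large step.

As far as these compounds go, whether an amine or a longer chain such as propoxy would be tolerated in this place remains open. For the compounds shown here, compound 2 differs from compound 3 in more than one place, so no step between them can be read.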